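Swapping Trifluoromethyl for Chloro on the Urea Aryl Ring

A few compounds are considered here, and "the series" means these few. Any claim that something is new, unique, unknown or untested is made for them only; others in the source may bear on it.

Compound 3 `COc1cc(Cl)cc(-c2nn(-c3cccc(NC(=O)Nc4ccc(Cl)c(C(F)(F)F)c4)c3)cc2-c2ccncc2)c1` is one of three closely related ureas measured in a functional assay on SNB-19 cells (Homo sapiens) for inhibition, read by sulforhodamine B assay, with a stated time of 48 h, tested at 1 uM; on this read-out lower numbers stand for a stronger effect and higher numbers for a weaker effect at the one concentration tested. Compound 3 gives 87%, the lowest of the three numbers. Compound 2 `O=C(Nc1cccc(-n2cc(-c3ccncc3)c(-c3cc(O)cc(Cl)c3)n2)c1)Nc1ccc(Cl)c(Cl)c1` gives 90%, which lies within the scatter of compound 3, while compound 1 `O=C(Nc1cccc(-n2cc(-c3ccncc3)c(-c3cc(O)cc(Cl)c3)n2)c1)Nc1ccc(Cl)c(C(F)(F)F)c1` gives 104%, separated from compound 3 by a step beyond the scatter: a number 17 percentage points lower from compound 1 to compound 3 (beyond the scatter).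

Compound 4 `COc1cc(Cl)cc(-c2nn(-c3cccc(NC(=O)Nc4ccc(Cl)c(Cl)c4)c3)cc2-c2ccncc2)c1` differs from compound 3 in a single place: chloro in place of trifluoromethyl on an aromatic carbon. The chloro enters on an aromatic carbon ortho to a chloro group and meta to a large group.

The same change has been measured once already: a number 14 percentage points lower from compound 1 to compound 2 (beyond the scatter). Within the data shown here, that is the only step bearing on the question, and it points to a modest fall. The step of a number 17 percentage points lower from compound 1 to compound 3 (beyond the scatter) shows that compound 4 starts from a lower point, and the two changes need not add in full. The expected step in this assay is therefore a number 10 percentage points lower from compound 3 to compound 4 (within the scatter). Compound 4 is estimated at 77%, between 60% and 94%.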

Compound 4, a percentage reported as activity, at one concentration (the size of the read-out at that concentration, not a potency): 89%
Beside the measured number, compound 4's estimate is 12 percentage points below it; the measured number falls inside the stated range.
By their numbers in this assay, from the lowest: compounds 3, 4 and 2 (each within the scatter of the next); then compound 1.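

Swapping trifluoromethyl for chloro does not act alike on both cores in this assay. With methyl on the oxygen, the swap gives a number 2 percentage points higher from compound 3 to compound 4 (within the scatter), so the drop seen with the free hydrogen on that oxygen does not recur: the same change on two cores in this assay, a number 14 percentage points lower (beyond the scatter) from compound 1 to compound 2 and a number 2 percentage points higher (within the scatter) from compound 3 to compound 4, 16 percentage points apart, beyond the scatter of two such steps

Read the other way, adding that methyl to a compound already carrying 3,4-dichlorophenyl gives a number 1 percentage points lower from compound 2 to compound 4 (within the scatter), so this change also depends on its partner: the same change on two cores in this assay, a number 17 percentage points lower (beyond the scatter) from compound 1 to compound 3 and a number 1 percentage points lower (within the scatter) from compound 2 to compound 4, 16 percentage points apart, beyond the scatter of two such steps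

The two changes therefore do not add up, since either one alone reaches the level of both together.

As far as these compounds go, it remains open whether a different group at this place, such as a nitrile or an amine, would take the number clearly below that of compound 2, compound 3 and compound 4. The effect of these compounds at other concentrations also remains open.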